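The compounds below may be only part of what the source reports. "The series", "measured", "known", "first", "only" and "open" are said of these compounds alone.

Measured compounds:
Compound 1, `O=C(NC(=S)Nc1nc2cc(Br)ccc2s1)c1cccs1`: in a functional assay on MCF7 cells (Homo sapiens) for cytotoxicity, read by MTT assay, with a stated time of 24 h (on this read-out lower numbers stand for stronger inhibition and higher numbers for weaker inhibition), compound 1 gives 24200 nM.
Compound 2, `Nc1ccc2sc(NC(=S)NC(=O)c3cccs3)nc2c1`: in this assay compound 2 gives 28400 nM.

Compound 2 holds the higher of the two numbers in this assay, yet its gap to compound 1 is small: a 1.2-fold higher number from compound 1 to compound 2 (0.07 log units; within the scatter), a step within the scatter, so the two compounds cannot be ordered against each other. Compound 3, `CCCCC(=O)NC(=S)Nc1nc2cc(N)ccc2s1`, keeps the amino group and the shared core of compound 2 and alters only the group on the carbonyl carbon: butyl in place of thiophen-2-yl on a carbonyl carbon. Among the measured compounds shown here, the single step on record, amino in place of bromo, concerns a different part of the molecule and says nothing about the carbonyl side. For the measured compounds named here, with no comparable step in this assay, the size of this change cannot be read from the data, and compound 3 is therefore expected to stay close to compound 2, the estimated step being a 1.1-fold higher number from compound 2 to compound 3 (0.02 log units; within the scatter), with no direction beyond the scatter. For compound 3 the estimate in this assay is 30000 nM, with a range from 12000 nM to 80000 nM.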

Compound 3, half-maximal inhibitory concentration: 44700 nM
For compound 3 the middle estimate is 1.5-fold (0.17 log units) below the measured one; measured number inside the range.
By their numbers in this assay, from the lowest: compounds 1, 2 and 3 (each within the scatter of the next).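

The carbonyl side of the molecule, which compounds 1 and 2 left unchanged, now has a step of its own: in this assay, butyl in place of thiophen-2-yl on a carbonyl carbon gives a 1.6-fold higher number from compound 2 to compound 3 (0.20 log units; within the scatter), and that step lies within the scatter. At this position, then, a five-membered aromatic ring with one hetero atom was exchanged for a chain with no ring, and the one hydrogen-bond acceptor counted for thiophen-2-yl went with it, without a step beyond the scatter in this cell read-out. No measurement is available that would explain this result.

The compounds shown leave open whether a phenyl ring, a longer chain such as octyl, or a carboxylic acid on the carbonyl carbon would move the number beyond the scatter, since neither of the two places varied so far has yet produced such a step. They also leave open whether butyl and thiophen-2-yl would stay as close with bromo in place of amino on the aromatic carbon, with the rest of the molecule held the same.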